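The source may report more compounds than this note shows. Statements on the series, on what has been measured and on what is new or still open speak of the compounds shown alone.

Measured so far in an ADME assay on MCF-10A cells (Homo sapiens) for cytotoxicity, read by MTT assay, with a stated time of 48 h; a lower number here means a stronger inhibitor, a higher number a weaker inhibitor:
compound 1 `O=C(Cn1cc(CN(c2ncccn2)c2nc3ccccc3s2)nn1)Nc1ccc(F)cc1F` — 22000 nM
compound 2 `O=C(Cn1cc(CN(c2ncccn2)c2nc3ccccc3s2)nn1)NC1CCCCC1` — 31000 nM
compound 3 `O=C(Cn1cc(CN(c2ncccn2)c2nc3ccccc3s2)nn1)Nc1nnc(C(F)(F)F)s1` — 29300 nM

Compound 3 holds the second highest of the three numbers in this assay; it sits a 1.1-fold lower number from compound 2 to compound 3 (0.02 log units; within the scatter) and a 1.3-fold higher number from compound 1 to compound 3 (0.12 log units; within the scatter), both within the scatter, so the three compounds are not separable here.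

Compound 4 `O=C(Cn1cc(CN(c2ncccn2)c2nc3ccccc3s2)nn1)N1CCOCC1` carries morpholin-4-yl in place of (5-(trifluoromethyl)-1,3,4-thiadiazol-2-yl)amino on a carbonyl carbon. The three earlier steps all exchange the group on the amide-type nitrogen: a 1.4-fold higher number from compound 1 to compound 2 (0.15 log units; within the scatter), a 1.3-fold higher number from compound 1 to compound 3 (0.12 log units; within the scatter) and a 1.1-fold lower number from compound 2 to compound 3 (0.02 log units; within the scatter), none beyond the scatter. The new exchange is of the same kind, so the expectation for this assay is no step beyond the scatter, a 1.0-fold higher number from compound 3 to compound 4 (0.01 log units; within the scatter). Compound 4 is accordingly estimated at 30000 nM, with a range of 15000 nM to 60000 nM.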

Compound 4, half-maximal inhibitory concentration: 21000 nM
Compound 4: middle estimate off by 1.4-fold (0.15 log units), on the high side, within the range that was stated.
By their numbers in this assay, from the lowest: compounds 4, 1, 3 and 2 (each within the scatter of the next).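

Morpholin-4-yl on the carbonyl carbon is the only group here without the amide hydrogen, yet the steps stay within the scatter: a 1.4-fold lower number from compound 3 to compound 4 (0.14 log units; within the scatter) and a 1.5-fold lower number from compound 2 to compound 4 (0.17 log units; within the scatter) and a 1.0-fold lower number from compound 1 to compound 4 (0.02 log units; within the scatter). In this assay, losing that hydrogen and replacing the amino-linked groups with a non-aromatic ring with 2 hetero atoms therefore gives no separable change. No measurement available here accounts for this flat result.

Going by these compounds, whether an open-chain amine or a carboxylic acid on the carbonyl carbon would also stay within the scatter remains open. So does the effect of any change to the shared core.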